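The compounds below may be only part of what the source reports. "The series", "measured", "known", "first", "only" and "open" are said of these compounds alone.

Working notes on the series. Compound 2 `COc1ccc(Cl)cc1-n1ncc(-c2nnc(-c3ccc(Cl)c(Cl)c3)o2)c1C` stands lowest of the two numbers in hand: in a physicochemical assay for lipophilicity, using the shake flask method, measured as octanol-water partition (a higher number here means a more lipophilic compound, a lower number a more polar compound), compound 2 gives 5.57, while compound 1 `COc1ccc(Cl)cc1-n1ncc(-c2nnc(-c3ccc(C)c([N+](=O)[O-])c3)o2)c1C` gives 6.42 in this assay, so that compound 2 sits at the polar end of the pair. Going by the values given here, the one step measured so far is a number 0.85 log units lower from compound 1 to compound 2 (beyond the scatter).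

Compound 3 `COc1ccc(Cl)cc1-n1ncc(-c2nnc(-c3ccc(C)c(Br)c3)o2)c1C` is not yet measured. It differs from compound 2 in one place: 3-bromo-4-methylphenyl in place of 3,4-dichlorophenyl on an aromatic carbon. Among the compounds with values here, the only step recorded, a number 0.85 log units lower from compound 1 to compound 2 (beyond the scatter), concerns a different pair of groups exchanged at the same aromatic carbon, so it sets a rough scale for what an exchange at this place can do but does not speak directly to the present one. Both groups exchanged here are of the same heavy-atom count and both carry no hydrogen-bond donors or acceptors, so a step in this assay no larger than the usual scatter is expected, if anything slightly upward. For compound 3 the estimate in this assay is 5.75, expected to fall between 5.35 and 6.15, which corresponds to an expected step of a number 0.18 log units higher from compound 2 to compound 3 (within the scatter).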

Compound 3, partition coefficient: 5.19
Compound 3: the middle estimate sits 0.56 log units above what was measured, and the stated range ends above it.
By their numbers in this assay, from the lowest: compound 3; then compound 2; then compound 1.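

In this assay the exchange of 3,4-dichlorophenyl for 3-bromo-4-methylphenyl gives a number 0.38 log units lower from compound 2 to compound 3 (beyond the scatter), so at this aromatic carbon two groups with the same heavy-atom count, and with no hydrogen-bond donors or acceptors on either side, still give a step that can be told from the scatter. With the methyl kept, bromo in place of nitro gives a number 1.23 log units lower from compound 1 to compound 3 (beyond the scatter), the largest step in the set so far, which leaves the compound carrying the 4-methyl-3-nitrophenyl group highest of the three, with its steps to both others beyond the scatter. No measurement at hand bears on why either number moves as it does.

The step from compound 2 to compound 3 changes two substituents on the phenyl ring at once, so the compounds shown leave open how much of it belongs to the bromo and how much to the methyl. They also leave open what an amine, a carboxylic acid or a longer alkyl chain on that phenyl ring would do to the number, since only halogen, methyl and nitro substituents appear there.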